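Hydrazide series: cytotoxicity at the amine substituent

This account rests on a few compounds, and the source may have more. Where it says the series, first, only, none or still open, it means among the compounds named here.

Three measured compounds share one core: compound 1 is `COC(=O)N[C@H](C(=O)NN(CCC[C@@](O)(Cc1ccccc1)C(=O)N[C@H]1c2ccccc2C[C@H]1O)Cc1ccc(N(C)C)cc1)C(C)(C)C`, compound 2 is `COC(=O)N[C@H](C(=O)NN(CCC[C@@](O)(Cc1ccccc1)C(=O)N[C@H]1c2ccccc2C[C@H]1O)CC(C)C)C(C)(C)C` and compound 3 is `COC(=O)N[C@H](C(=O)NN(CCC[C@@](O)(Cc1ccccc1)C(=O)N[C@H]1c2ccccc2C[C@H]1O)Cc1ccc(-c2ccccn2)cc1)C(C)(C)C`. In an ADME assay on MT4 cells (Homo sapiens) for cytotoxicity (a lower number here means that less compound is tolerated, a higher number that more compound is tolerated), compound 1 gives > 10000 nM, which is a limit of the assay and not a number. Compound 2 in this assay gives > 10000 nM, again a limit. Compound 3 in this assay gives > 10000 nM, also a limit. Compound 2 therefore stands at the same limit as the other two measured compounds, and the steps a step that the two limits leave unreadable from compound 1 to compound 2, a step that the two limits leave unreadable from compound 1 to compound 3 and a step that the two limits leave unreadable from compound 2 to compound 3 cannot be sized because of the limit of > 10000 nM in this assay, at which 3 of the 3 values shown sit.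

Compound 4, `COC(=O)N[C@H](C(=O)NN(CCC[C@@](O)(Cc1ccccc1)C(=O)N[C@H]1c2ccccc2C[C@H]1O)Cc1ccc(-c2ccccc2)cc1)C(C)(C)C`, differs from compound 2 by 4-phenylphenyl in place of isopropyl on a saturated chain carbon bound to an amine nitrogen. The step from compound 2 to compound 3 is the closest parallel, since it also exchanges isopropyl for a larger aromatic group on the same saturated chain carbon, but its size is unreadable. The step that the limit leaves unreadable from compound 2 to compound 4 is therefore expected to be none beyond the scatter, on the weak ground that every measured value sits at the limit. The estimate for compound 4 in this assay is 12000 nM, with a range from 5000 nM to 40000 nM, and it is expected that the assay again reports only a limit.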

Compound 4, half-maximal cytotoxic concentration: 7500 nM
Estimate against measurement, compound 4: 1.6-fold (0.20 log units) above; low and high end bracket the measured number.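

In this assay, going by these compounds alone, compound 4, with 4-phenylphenyl on a saturated chain carbon bound to an amine nitrogen, gives 7500 nM, the first value in this set that is a number and not a limit. Against the three compounds held at the limit, the change reads as an at least 1.3-fold lower number from compound 2 to compound 4 (0.12 log units; that floor lies within the scatter), as an at least 1.3-fold lower number from compound 3 to compound 4 (0.12 log units; that floor lies within the scatter) and as an at least 1.3-fold lower number from compound 1 to compound 4 (0.12 log units; that floor lies within the scatter), so each comparison gives only a floor and none shows a change beyond the scatter. These floors give no true size, and the steps among compound 1, compound 2 and compound 3 still cannot be read, because of this feature of the data: the limit of > 10000 nM in this assay, at which 3 of the 4 values shown sit.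

On these data alone, whether compound 4 truly lies apart from the other three remains open, since a number on one side and a limit on the other cannot settle it. Also open, as far as these compounds go, is what a cyclohexyl or a 4-carboxyphenyl group would give on the same saturated chain carbon, and so whether the number of compound 4 belongs to the 4-phenylphenyl group specifically or to large groups at this place in general.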